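A few compounds are considered here, and "the series" means these few. Any claim that something is new, unique, unknown or untested is made for them only; others in the source may bear on it.

Measured compounds:
- compound 1 `COC(=O)N[C@H](C(=O)N1CCC[C@H]1C(=O)Nc1ccc([C@H]2CC[C@H](c3ccc(NC(=O)[C@@H]4CCCN4C(=O)[C@@H](NC(=O)OC)C(C)C)cc3)N2c2ccc(C(F)(F)F)cc2)cc1)C(C)C`: 4.9 h in an ADME assay on the whole organism for metabolic stability, with Rattus norvegicus as the target, at a dose of 3 mg/kg by the oral route; a higher number here means that the compound lasts longer, a lower number that the compound disappears faster
- compound 2 `COC(=O)N[C@H](C(=O)N1CCC[C@H]1C(=O)Nc1ccc([C@@H]2CC[C@@H](c3ccc(NC(=O)[C@@H]4CCCN4C(=O)[C@@H](NC(=O)OC)C(C)C)cc3)N2c2ccc(F)cc2)cc1)C(C)C`: 3 h in this assay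

Compound 2 stands lowest of the two numbers in this assay; its nearest neighbour is compound 1, whose number is higher by a margin that falls within the scatter, so the two cannot be told apart on these data. Compound 3 `COC(=O)N[C@H](C(=O)N1CCC[C@H]1C(=O)Nc1ccc([C@@H]2CC[C@@H](c3ccc(NC(=O)[C@@H]4CCCN4C(=O)[C@@H](NC(=O)OC)C(C)C)cc3)N2c2ccc(C(F)(F)F)cc2)cc1)C(C)C` has not yet been measured. It differs from compound 2 in one place: trifluoromethyl in place of fluoro on an aromatic carbon. Among the measured compounds shown here, no step between measured compounds covers this exchange directly. Given that compound 2 gives 3 h and that the two measured half-lives lie within the scatter of each other, the step is expected to be small, with no direction beyond the scatter. Compound 3 is expected to give 4 h, between 2 h and 8 h, a step of a 1.3-fold higher number from compound 2 to compound 3 (0.12 log units; within the scatter).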

Compound 3, half-life: 12.1 h
Beside the measured number, compound 3's estimate is 3.0-fold (0.48 log units) below it; measured number outside the range, above it.
By their numbers in this assay, from the lowest: compounds 2 and 1 (each within the scatter of the next); then compound 3.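

At the place on the six-membered aromatic ring para to a large group, the exchange of fluoro for trifluoromethyl turns out not to be neutral in this assay, giving a 4.0-fold higher number from compound 2 to compound 3 (0.61 log units; beyond the scatter). With the 4-(trifluoromethyl)phenyl group held constant, the half-life also responds to the configuration as drawn, with a 2.5-fold higher number from compound 1 to compound 3 (0.39 log units; beyond the scatter), and this step can be put down to stereochemistry alone because of one point: the fact that compounds 1 and 3 differ only in the configuration as drawn. Compound 1 and compound 2 differ in both places at once, so that pair could separate neither effect.

From the compounds shown here alone, it remains open whether the exchange gives a similar step in the configuration of compound 1, and whether the configuration matters as much with fluoro in place. Going by these compounds, how a chlorine, a nitrile or a methoxy group at this place would read in this assay is also open.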